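The source may hold more compounds than are shown below. What is called first, only, known or untested is meant among the compounds shown, and "the series" means these compounds.

Measured compounds, all in an assay on isolated protein for agonist activity at Bile acid receptor (Homo sapiens), read by TR-FRET; a higher number here means that more compound is needed for the effect, a lower number that less compound is needed:
- compound 1, `CCC(CC)n1c(-c2ccc(OCc3c(-c4c(Cl)cccc4Cl)noc3C(C)C)cc2)nc2ccc(C(=O)O)cc21`: 26.5 nM
- compound 2, `CC(C)c1onc(-c2c(Cl)cccc2Cl)c1COc1ccc(-c2nc3ccc(C(=O)O)cc3n2CC2CCCCC2)c(F)c1`: "not determined" (no result reported)
- compound 3, `CC(C)c1onc(-c2c(Cl)cccc2Cl)c1COc1ccc(-c2nc3ccc(C(=O)O)cc3n2CC2CCCCC2)cc1`: 19.9 nM

Compound 3 carries the lowest of the two numbers in this assay, and its nearest neighbour is compound 1, where the step of a 1.3-fold lower number from compound 1 to compound 3 (0.12 log units; within the scatter) stays within the scatter, so the two compounds cannot be ordered. Compound 2 has no result in this assay and contributes no number.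

Compound 4, `CC(C)c1onc(-c2c(Cl)cccc2Cl)c1COc1ccc(-c2nc3ccc(C(=O)O)cc3n2CC2CCCCC2)c(Cl)c1`, is the next entry. It differs from compound 3 only in chloro in place of hydrogen on an aromatic carbon. Going by the values given here, no measured step touches this change: the one step, from compound 1 to compound 3, concerns the substituent on the aromatic nitrogen and leaves this ring untouched, and compound 2, the only other compound with a substituent at the same place, has no number. Among the compounds with values here, the single measured step was small and within the scatter, so the series so far shows no move beyond the scatter, and nothing here points in either direction for a halogen at this position. Compound 4 is therefore expected at 25 nM, with a range from 8 nM to 80 nM. That estimate means an expected step of a 1.3-fold higher number from compound 3 to compound 4 (0.10 log units; within the scatter), within the scatter, with a wide range to reflect the absence of any bearing step.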

Compound 4, half-maximal effective concentration: 66.1 nM
For compound 4 the middle estimate is 2.6-fold (0.42 log units) below the measured one; low and high end bracket the measured number.
By their numbers in this assay, from the lowest: compounds 3 and 1 (each within the scatter of the next); then compound 4.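

In this assay, going by these compounds alone, the change to chloro in place of hydrogen on an aromatic carbon gives a 3.3-fold higher number from compound 3 to compound 4 (0.52 log units; beyond the scatter) and is the first step beyond the scatter, though of modest size. Within the data shown here, this position, ortho to a large group and meta to a large group, therefore does not tolerate every substituent without a change in the number, which the earlier compounds could not show. Among these compounds, the only earlier step, a 1.3-fold lower number from compound 1 to compound 3 (0.12 log units; within the scatter), concerned the substituent on the aromatic nitrogen and stayed within the scatter, so the entering chloro, with its 1 heavy atom, has moved the number further than that exchange did, and no measurement available here bears on why.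

As far as these compounds go, compound 2 has no number, so whether fluoro at this place also raises the number, or whether the rise is particular to chloro, stays open. Also open, from the compounds shown here alone, are how a methyl, a methoxy or an amine would read at this place, and whether chloro gives a similar step with pentan-3-yl on the aromatic nitrogen in place of cyclohexylmethyl.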